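Removing the chloro group from compound 2

This account rests on a few compounds, and the source may have more. Where it says the series, first, only, none or still open, it means among the compounds named here.

Compound 1 `COc1ccc(-c2nc3sc(-c4ccccc4)cn3n2)cc1` gives 35%
Compound 2 `Clc1ccc(-c2cn3nc(-c4ccccc4)nc3s2)cc1` gives 6%
Compound 3 `COc1ccc(-c2nc3sc(-c4ccc(Cl)cc4)cn3n2)cc1` gives 30.5%

In a functional assay on CCRF-CEM cells (Homo sapiens) for inhibition, read by sulforhodamine B assay, with a stated time of 48 h, tested at 10 uM (a lower number here means less inhibition of growth, a higher number more inhibition of growth at the concentration tested), compound 2 has the lowest of the three numbers, at 6% as shown. Compound 4 `c1ccc(-c2nc3sc(-c4ccccc4)cn3n2)cc1` is still unmeasured. It has hydrogen in place of chloro on an aromatic carbon. The closest measured change is the same swap in reverse: a number 4.5 percentage points lower from compound 1 to compound 3 (within the scatter). The other measured step, a number 24.5 percentage points higher from compound 2 to compound 3 (beyond the scatter), adds a methoxy group, and compound 4 lacks that group just as compound 2 does. That larger step therefore offers no reason to expect a rise. The expected change is a number 4 percentage points higher from compound 2 to compound 4 (within the scatter), which means no clear shift in this assay is expected. For compound 4 the estimated value is 10%, with an expected range from 0% to 25% as the likely outcome.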

Compound 4, percent growth inhibition at one concentration: 13%
Compound 4: middle estimate off by 3 percentage points, on the low side, within the range that was stated.
By their numbers in this assay, from the lowest: compounds 2 and 4 (each within the scatter of the next); then compounds 3 and 1 (each within the scatter of the next).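

Within this assay, removing the chloro group from the 4-chlorophenyl ring gives a number 7 percentage points higher from compound 2 to compound 4 (within the scatter) and so makes no clear difference. This now holds with or without the methoxy group: the same change on two cores in this assay, a number 4.5 percentage points lower (within the scatter) from compound 1 to compound 3 and a number 7 percentage points lower (within the scatter) from compound 4 to compound 2, 2.5 percentage points apart, within the scatter of two such steps. The methoxy group is the change that counts, with a number 22 percentage points lower from compound 1 to compound 4 (beyond the scatter) when it is lost, and its effect holds with or without the chloro group: the same change on two cores in this assay, a number 24.5 percentage points higher (beyond the scatter) from compound 2 to compound 3 and a number 22 percentage points higher (beyond the scatter) from compound 4 to compound 1, 2.5 percentage points apart, within the scatter of two such steps.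

The compounds shown leave open whether this rise is specific to methoxy or would also come with a hydroxy group, an amine or a longer ether chain in its place.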